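The compounds below may be only part of what the source reports. "The series", "measured", "known", "first", "only" and "open" are said of these compounds alone.

Measured compounds in an assay on CHO-K1 cells for antagonist activity at transient receptor potential cation channel subfamily V member 1 (Homo sapiens), read by FLIPR; on this read-out higher numbers stand for weaker inhibition and lower numbers for stronger inhibition:
compound 1, `CC1CCN(CCCSc2nc(C(F)(F)F)ccc2CNC(=O)C(C)c2ccc(NS(C)(=O)=O)c(F)c2)CC1`, gives 217 nM
compound 2, `COC(=O)CCSc1nc(C(F)(F)F)ccc1CNC(=O)C(C)c1ccc(NS(C)(=O)=O)c(F)c1`, gives 1100 nM
compound 3, `Cc1ccc(CSc2nc(C(F)(F)F)ccc2CNC(=O)C(C)c2ccc(NS(C)(=O)=O)c(F)c2)cc1`, gives 764 nM

Compound 3 holds the second highest of the three numbers in this assay. Among the measured compounds shown here, its nearest neighbour is compound 2, at a gap within the usual scatter, so the two cannot be ranked against each other; the only step that separates compound 3 from the rest is the one to compound 1, a 3.5-fold higher number from compound 1 to compound 3 (0.55 log units; beyond the scatter). The other two steps through the series read a 5.1-fold higher number from compound 1 to compound 2 (0.70 log units; beyond the scatter) and a 1.4-fold lower number from compound 2 to compound 3 (0.16 log units; within the scatter).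

Compound 4, `CC(C(=O)NCc1ccc(C(F)(F)F)nc1SCCc1ccccc1)c1ccc(NS(C)(=O)=O)c(F)c1`, has not yet been measured. It differs from compound 3 by benzyl in place of 4-methylphenyl on a saturated chain carbon bound to a sulfur; the two share the same atoms and the same core, rearranged only in the chain that hangs from the sulfur. For the measured compounds named here, no measured step reproduces this change. The step from compound 2 to compound 3, which also exchanges the group on the saturated chain carbon bound to the sulfur, stayed within the scatter, while the step from compound 1 to compound 3 was modest. Going by the values given here, nothing among the measured steps points to a shift in either direction for compound 4, so for compound 4 a step of a 1.0-fold higher number from compound 3 to compound 4 (0.02 log units; within the scatter) is expected, no larger than the scatter. Compound 4 is therefore estimated at 800 nM in this assay, with a range from 300 nM to 2500 nM.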

Compound 4, half-maximal inhibitory concentration: 111 nM
For compound 4 the middle estimate is 7.2-fold (0.86 log units) above the measured one, and the stated range ends above it.
By their numbers in this assay, from the lowest: compounds 4 and 1 (each within the scatter of the next); then compounds 3 and 2 (each within the scatter of the next).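

In this assay, phenethylsulfanyl in place of (4-methylbenzyl)sulfanyl gives a 6.9-fold lower number from compound 3 to compound 4 (0.84 log units; beyond the scatter), so this position responds to how the same seven carbons are arranged, even though the ring type and the counted hydrogen-bond donors and acceptors stay the same, whereas the exchange of end groups between compound 2 and compound 3 had stayed within the scatter. Phenyl in place of methoxycarbonyl gives a 9.9-fold lower number from compound 2 to compound 4 (1.00 log units; beyond the scatter), while phenyl in place of (4-methylpiperidin-1-yl)methyl gives a 2.0-fold lower number from compound 1 to compound 4 (0.29 log units; within the scatter), within the scatter, so among these compounds a value in the range of compound 1 does not depend on the piperidine, and a chain ending in an all-carbon ring can reach it. Nothing on hand accounts for these differences in terms of mechanism.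

The change from compound 3 to compound 4 alters the chain and removes the ring methyl together, so the compounds shown cannot assign the step to either; benzylsulfanyl and (4-methylphenethyl)sulfanyl would separate the two. Also open, from the compounds shown here alone, is how a longer chain such as 3-phenylpropyl, or a carboxylic acid at the chain end, would read in this assay.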